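The source may hold more compounds than are shown below. What is called first, only, known or untested is meant among the compounds shown, and "the series" means these compounds.

Compound 2 `CCCCCC[C@H](O)C/C=C\CCCCCCCc1cc(O)cc(O)c1` gives 76000 nM in an ADME assay on Vero cells (Homo sapiens) for cytotoxicity against Vero (Chlorocebus sabaeus), read by MTT assay; on this read-out higher numbers stand for weaker inhibition and lower numbers for stronger inhibition. Compound 1 `CC/C=C\C/C=C\C/C=C\CCCCCCCc1cc(O)cc(O)c1` gives 104000 nM, and compound 3 `CC/C=C\C/C=C\C/C=C\CCCCCCCc1cc(OC(C)=O)cc(OC(C)=O)c1` gives 138000 nM; both numbers lie within the scatter of compound 2, so the three compounds cannot be told apart on this read-out. Compound 4 `CC/C=C\C[C@@H](O)CC/C=C\CCCCCCCc1cc(O)cc(O)c1` differs from compound 2 by a group of 8 heavy atoms (7 carbon, 1 oxygen; no ring) in place of a group of 8 heavy atoms (7 carbon, 1 oxygen; no ring), on a saturated chain carbon bound to a double-bonded chain carbon: the 1-hydroxyheptyl leaves and a group carrying one double bond outside aromatic rings enters, on a saturated chain carbon bound to a double-bonded chain carbon. Among the measured compounds shown here, the one comparable step, a 1.4-fold lower number from compound 1 to compound 2 (0.14 log units; within the scatter), likewise exchanged groups at that place and stayed within the scatter. No step beyond the scatter is therefore expected here. Compound 4 is estimated at 80000 nM, with a range from 40000 nM to 160000 nM. That estimate means an expected step of a 1.1-fold higher number from compound 2 to compound 4 (0.02 log units; within the scatter).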

Compound 4, half-maximal inhibitory concentration: 30000 nM
Estimate against measurement, compound 4: 2.7-fold (0.43 log units) above; measured number below the stated range.
By their numbers in this assay, from the lowest: compound 4; then compounds 2, 1 and 3 (each within the scatter of the next).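

At this place, on a saturated chain carbon bound to a double-bonded chain carbon, an exchange of groups now moves the number in this assay beyond the scatter, though only modestly (a 2.5-fold lower number from compound 2 to compound 4 (0.40 log units; beyond the scatter); a 3.5-fold lower number from compound 1 to compound 4 (0.54 log units; beyond the scatter)). The earlier exchange here stayed within the scatter, and this step appears even though the 1-hydroxyheptyl and the entering group have the same counts of heavy atoms, donors and acceptors. No measurement at hand explains the step. Still open, from the compounds shown here alone, is whether the double bond or the placement of the hydroxyl carries the change, and how an amine or a carboxylic acid in place of that hydroxyl would read.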